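Replacing phenoxy with trifluoromethoxy in a cytotoxicity screen

A few compounds are considered here, and "the series" means these few. Any claim that something is new, unique, unknown or untested is made for them only; others in the source may bear on it.

Measured so far:
Compound 1 `CCOC(=O)c1c(-c2cccc(Oc3ccccc3)c2)[nH]c2cc(OC)ccc2c1=O`, in an ADME assay on BJ cells (Homo sapiens) for cytotoxicity, read by luminescence, with a stated time of 72 h (on this read-out lower numbers stand for an effect already at smaller amounts and higher numbers for an effect only at larger amounts of compound), compound 1 gives > 21500 nM, which is a limit of the assay rather than a number.
Compound 2 `CCOC(=O)c1c(-c2cccc(OC(F)(F)F)c2)[nH]c2cc(OC)ccc2c1=O`, compound 2 gives > 21500 nM, again a limit.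
Compound 3 `CCOC(=O)c1c(-c2cccc(Oc3ccccc3)c2)[nH]c2cc(F)cc(F)c2c1=O`, compound 3 gives > 21500 nM, also a limit.

Compound 1 and compound 2 share a core and differ by trifluoromethyl in place of phenyl on an oxygen on an aromatic ring. The step that the two limits leave unreadable from compound 1 to compound 2 is unreadable because of the limit of > 21500 nM in this assay, at which 3 of the 3 values shown sit. The difference between the cores of compound 1 and compound 3 is not broken down here. Compound 4 `CCOC(=O)c1c(-c2cccc(OC(F)(F)F)c2)[nH]c2cc(F)cc(F)c2c1=O` has not been measured; it differs from compound 3 by trifluoromethyl in place of phenyl on an oxygen on an aromatic ring, the same kind of change. The expectation for compound 4 rests on the unreadable step from compound 1 to compound 2 and on compound 3 sitting at > 21500 nM, a limit. For compound 4 the expected step is a step that the limit leaves unreadable from compound 3 to compound 4. Compound 4 is therefore estimated at 30000 nM, between 12000 nM and 100000 nM.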

Compound 4, half-maximal effective concentration: > 21500 nM
Compound 4: no number, only a limit (the forecaster's own chance of this, stated with the estimate: 85%); the middle value lies beyond the limit too.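

Going by these compounds alone, no step from compound 3 to compound 4 can be read, because both values are limits and not numbers: the limit of > 21500 nM in this assay, at which 4 of the 4 values shown sit. The compounds shown leave open whether trifluoromethoxy in place of phenoxy changes the result in this assay at all.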